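The source may report more compounds than this note shows. Statements on the series, on what has been measured and on what is new or still open speak of the compounds shown alone.

Measured compounds in a functional assay on the whole organism (strain CD-1) with Mus musculus as the target, with a stated time of 2 h; on this read-out lower numbers stand for an effect already at smaller amounts and higher numbers for an effect only at larger amounts of compound:

compound 1 `CC1(c2ccccc2)CC(=O)N(CC(=O)N2CCN(c3ccccc3F)CC2)C1=O`, 300 mg/kg
compound 2 `CC1(c2ccccc2)CC(=O)N(CC(=O)N2CCN(c3ccccc3)CC2)C1=O`, 300 mg/kg

The account concerns compound 3 `CC1(c2ccccc2)CC(=O)N(CC(=O)N2CCN(c3ccccc3Cl)CC2)C1=O`, which has not yet been measured in this assay. Compound 2 stands level with compound 1 at the digits shown: the step of no change at the digits printed from compound 1 to compound 2 (within the scatter), hydrogen in place of fluoro on an aromatic carbon, left the minimum effective dose unchanged within the scatter.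

The change that leads from compound 2 to compound 3 is chloro in place of hydrogen on an aromatic carbon. Within the data shown here, it sits at the same place as the earlier change, on the aromatic carbon ortho to a large group, and the one step that bears on it, no change at the digits printed from compound 1 to compound 2 (within the scatter), showed no effect beyond the scatter when the halogen there was exchanged for hydrogen. Among the measured compounds shown here, with only that step to go on, no shift beyond the scatter is expected from compound 2 to compound 3; the estimated step is no change at the digits printed from compound 2 to compound 3 (within the scatter).

Compound 3 is therefore expected to give about 300 mg/kg in this assay, with a likely range from 150 mg/kg to 600 mg/kg.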

Compound 3, minimum effective dose: 100 mg/kg
Beside the measured number, compound 3's estimate is 3.0-fold (0.48 log units) above it; measured number outside the range, below it.
By their numbers in this assay, from the lowest: compound 3; then compounds 1 and 2 (each within the scatter of the next).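

In this assay, the aromatic carbon ortho to a large group proves not to be indifferent to what sits on it: chloro in place of hydrogen gives a 3.0-fold lower number from compound 2 to compound 3 (0.48 log units; beyond the scatter), a modest step but one beyond the scatter, whereas the earlier exchange of fluoro for hydrogen gave no change at the digits printed from compound 1 to compound 2 (within the scatter). The two halogens also part from each other at this place, with chloro in place of fluoro giving a 3.0-fold lower number from compound 1 to compound 3 (0.48 log units; beyond the scatter), so among these three compounds the lower number goes with chloro in particular and not with the presence of any halogen. Nothing available here accounts for this difference between chloro and fluoro.

The compounds shown leave open whether bromo, methyl or methoxy at this place would go with a lower number as chloro does, and whether chloro would do the same on another carbon of the ring. Going by these compounds, all three also share the rest of the structure, so it stays open whether the step from phenyl to 2-chlorophenyl would hold with a longer chain in place of the linker or with an ethyl group in place of the methyl on the core.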